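One ring stereocentre changed in compound 1

The source may hold more compounds than are shown below. What is called first, only, known or untested is meant among the compounds shown, and "the series" means these compounds.

compound 1 `Cc1cn([C@@H]2O[C@H](CO)[C@@H](CN=[N+]=[N-])[C@@H]2O)c(=O)[nH]c1=O`: > 100 uM (a limit)
compound 2 `Cc1cn([C@@H]2O[C@H](CO)[C@@H](CO)[C@@H]2O)c(=O)[nH]c1=O`: > 100 uM (a limit)

In a functional assay on CCRF-CEM cells (Homo sapiens) for antiproliferative activity, with a stated time of 72 h (on this read-out higher numbers stand for an effect only at larger amounts of compound and lower numbers for an effect already at smaller amounts), compound 1 stands at > 100 uM, which is a limit of the assay and not a number. Compound 2 is no different in kind, and the full picture so far is the limit of > 100 uM in this assay, at which 2 of the 2 values shown sit.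

Compound 3 `Cc1cn([C@@H]2O[C@H](CO)[C@@H](CN=[N+]=[N-])[C@H]2O)c(=O)[nH]c1=O` has not yet been measured. It relates to compound 1 in this way: the two compounds have the same atoms and bonds; at least one stereo element is drawn with a configuration in one of them and without one in the other: 1 of 5 stereo elements differ; a stereocentre at a saturated ring carbon is drawn S in compound 1 and R in compound 3. A stereocentre at a saturated ring carbon is drawn S in compound 1 and R in compound 3.

Among the compounds with values here, only one measured step exists, a step that the two limits leave unreadable from compound 1 to compound 2. It concerns hydroxy in place of azido, a different kind of change, and its size cannot be read. Within the data shown here, no step of known size can therefore be carried over, and no shift in either direction beyond the scatter is expected in this assay. The expectation is that this compound also ends at a limit, resting on compound 1 at > 100 uM, itself a limit.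

The expected change is a step that the limit leaves unreadable from compound 1 to compound 3.

Compound 3 is estimated at 150 uM, with an expected range from 60 uM to 400 uM.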

Compound 3, concentration for half-maximal effect: > 100 uM
Compound 3 gave a limit, no number; the forecaster's own chance of this, stated with the estimate: 90%; the middle value lies beyond the limit too.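

The step between compound 1 and compound 3 in this assay cannot be read, because both values are limits of the assay and not numbers: the limit of > 100 uM in this assay, at which 3 of the 3 values shown sit.

The compounds shown leave open whether changing this one ring stereocentre alters antiproliferative activity at all, since any difference would lie beyond the limit.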